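The compounds below may be only part of what the source reports. "The series", "measured", "known", "first", "only" and "open" are said of these compounds alone.

Compound 1 `CNC1=CC(=O)c2ccccc2C1=O` and compound 2 `O=C1C=C(N2CCCC2)C(=O)c2ccccc21` share the same core and differ only in the amine attached to a double-bonded ring carbon. In a functional assay on PC-3 cells (Homo sapiens) for antiproliferative activity, read by MTT assay (on this read-out higher numbers stand for weaker inhibition and lower numbers for stronger inhibition), compound 1 gives 93300 nM. For compound 2 the reading in this assay is > 200000 nM, which is a limit of the assay and not a number, so compound 2 stands only at the limit of > 200000 nM in this assay, at which 1 of the 2 values shown sits. The step of an at least 2.1-fold higher number from compound 1 to compound 2 (0.33 log units; beyond the scatter) shows that moving from methylamino to pyrrolidin-1-yl weakened the effect.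

Compound 3 `O=C1C=C(NCCO)C(=O)c2ccccc21` differs from compound 2 as follows: (2-hydroxyethyl)amino in place of pyrrolidin-1-yl on a double-bonded ring carbon. This brings back an open-chain amine of the kind seen in compound 1. Among the measured compounds shown here, the step of an at least 2.1-fold higher number from compound 1 to compound 2 (0.33 log units; beyond the scatter) is the only measured guide, and it ran the other way. Compound 3 is therefore expected to give a lower number, a step of an at least 2.2-fold lower number from compound 2 to compound 3 (0.34 log units; beyond the scatter). The estimate for compound 3 is 90000 nM, with a range from 30000 nM to 250000 nM.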

Compound 3, half-maximal inhibitory concentration: 107000 nM
The estimate for compound 3 lay 1.2-fold (0.08 log units) below the measured number; the measured number falls inside the stated range.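

Set against the ring amine of compound 2, the open chain of compound 3 gives an at least 1.8-fold lower number from compound 2 to compound 3 (0.27 log units; that floor lies within the scatter), so in this assay this step alone cannot firmly separate the two compounds. Compound 2 stands only at a limit of the assay, not at a number: the limit of > 200000 nM in this assay, at which 1 of the 3 values shown sits. The new information comes from the other comparison, a 1.1-fold higher number from compound 1 to compound 3 (0.06 log units; within the scatter): hydroxymethyl can be added to the open chain on this double-bonded ring carbon with no change that can be told from the scatter, so compound 1 and compound 3 read alike.

The compounds shown leave open whether the hydroxyl itself matters, which an ethylamino group at this ring carbon would help to answer. They also leave open how a longer chain, such as (3-hydroxypropyl)amino, or a morpholin-4-yl ring would read there.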